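The compounds below may be only part of what the source reports. "The series", "measured", "known", "first", "only" and "open" are said of these compounds alone.

The measured compounds in a functional assay on Caco-2 cells (Homo sapiens) for cytotoxicity, with a stated time of 48 h; a higher number here means a weaker inhibitor, a lower number a stronger inhibitor:
compound 1, `COc1ccc(-c2cc(COC(Cc3cn(C4CCN(Cc5ccc([N+](=O)[O-])cc5)CC4)nn3)c3ccc(Br)cc3)on2)cc1`, gives 3000 nM;
compound 2, `N#Cc1ccc(-c2cc(COC(Cc3cn(C4CCN(Cc5ccc([N+](=O)[O-])cc5)CC4)nn3)c3ccc(Br)cc3)on2)cc1`, gives 2000 nM;
compound 3, `COc1cccc(-c2cc(COC(Cc3cn(C4CCN(Cc5ccc([N+](=O)[O-])cc5)CC4)nn3)c3ccc(Br)cc3)on2)c1`, gives 5000 nM.

In this set the steps are small: a 1.7-fold higher number from compound 1 to compound 3 (0.22 log units; within the scatter), while a 2.5-fold higher number from compound 2 to compound 3 (0.40 log units; beyond the scatter). Compound 4, `N#Cc1cccc(-c2cc(COC(Cc3cn(C4CCN(Cc5ccc([N+](=O)[O-])cc5)CC4)nn3)c3ccc(Br)cc3)on2)c1`, has not yet been measured in this assay. It differs from compound 3 by cyano in place of methoxy on an aromatic carbon. The same kind of change is already measured between compound 1 and compound 2, namely (cyano in place of methoxy on an aromatic carbon), and there a 1.5-fold lower number from compound 1 to compound 2 (0.18 log units; within the scatter). The two cores differ by 3-methoxyphenyl in place of 4-methoxyphenyl on an aromatic carbon. The places are not identical: in the measured pair the change sits para to a large group, in the new pair meta to a large group, so it is the same kind of change, not the same change. Resting on a 1.5-fold lower number from compound 1 to compound 2 (0.18 log units; within the scatter), the expected step is a 1.5-fold lower number from compound 3 to compound 4 (0.18 log units; within the scatter). Compound 4 is therefore estimated at 3300 nM, with a likely range from 1500 nM to 8000 nM.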

Compound 4, half-maximal inhibitory concentration: 3000 nM
Compound 4: the middle estimate sits 1.1-fold (0.04 log units) above what was measured; measured number inside the range.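

In this assay, cyano in place of methoxy on the core of compound 3 gives a 1.7-fold lower number from compound 3 to compound 4 (0.22 log units; within the scatter), and the change reads alike on the two cores: the same change on two cores in this assay, a 1.5-fold lower number (0.18 log units; within the scatter) from compound 1 to compound 2 and a 1.7-fold lower number (0.22 log units; within the scatter) from compound 3 to compound 4, 1.1-fold (0.05 log units) apart, within the scatter of two such steps. Both steps lie within the scatter, so the pair shows that the change carries across these two cores without a visible difference, but not that it has a real effect on either. The other new steps also stay within the scatter, with 3-cyanophenyl in place of 4-cyanophenyl giving a 1.5-fold higher number from compound 2 to compound 4 (0.18 log units; within the scatter) and 3-cyanophenyl in place of 4-methoxyphenyl giving no change at the digits printed from compound 1 to compound 4 (within the scatter).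

The compounds shown carry only methoxy or cyano on this aromatic ring. They leave open how an amine or a carboxylic acid would read at the same place.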